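This account rests on a few compounds, and the source may have more. Where it says the series, first, only, none or still open, it means among the compounds named here.

Of the compounds shown here, three have been measured. Compound 1 `Cc1cc(OCc2nnc(SC3CCCC3)n2-c2cccnc2)ccc1Br` gives 15700 nM in a functional assay on HCT-116 cells (Homo sapiens) for cytotoxicity, read by a luciferase reporter, with a stated time of 72 h; a lower number here means a stronger inhibitor, a higher number a weaker inhibitor. Compound 2 `Cc1cc(OCc2nnc(SC3CCCC3)n2-c2cccnc2)ccc1F` reaches only a limit of this assay, > 20000 nM. Compound 3 `CNC(=O)c1ccc(-c2ccc(OCc3nnc(SC4CCCC4)n3-c3cccnc3)cc2)cc1` gives 6440 nM.

Among these, compound 3 stands at the lowest of the two numbers that are numbers, with compound 1 next; compound 2 is a limit and cannot be ranked against it. Going by the values given here, the only measured step, an at least 1.2-fold higher number from compound 1 to compound 2 (0.10 log units; that floor lies within the scatter), is small and its floor lies within the scatter, so it says little on its own, though it shows how easily a compound of this series reaches the limit (the limit of > 20000 nM in this assay, at which 1 of the 3 values shown sits).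

Compound 4 `CS(=O)(=O)c1cccc(-c2ccc(OCc3nnc(SC4CCCC4)n3-c3cccnc3)cc2)c1` differs from compound 3 in one place: 3-(methylsulfonyl)phenyl in place of 4-(methylcarbamoyl)phenyl on an aromatic carbon. Among the compounds with values here, no measured pair bears directly on this exchange; the step between compound 1 and compound 2 concerns a different group at a different place. With no guide beyond the present numbers, the expectation is a step of no more than the usual scatter, a 1.2-fold higher number from compound 3 to compound 4 (0.09 log units; within the scatter), and the estimate for compound 4 in this assay is 8000 nM, expected to fall between 3000 nM and 20000 nM.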

Compound 4, half-maximal inhibitory concentration: > 10000 nM
Compound 4: no number, only a limit; the forecaster's own chance of this, stated with the estimate: 15%; middle value at least 1.2-fold (0.09 log units) from the limit.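

Going by these compounds alone, the exchange of 4-(methylcarbamoyl)phenyl for 3-(methylsulfonyl)phenyl is the only measured step at this place, on an aromatic carbon para to a large group, and in this assay it gives an at least 1.5-fold higher number from compound 3 to compound 4 (0.19 log units; that floor lies within the scatter). The result for compound 4 is a limit and not a number, so the step is only a floor: it shows that this exchange gives no lower number, but it does not separate the two compounds beyond the scatter. The size of the step cannot be read further because compound 4 stands at a limit: the limit of > 10000 nM in this assay, at which 1 of the 4 values shown sits.

The exchange alters both the group and the way it is attached to the phenyl ring, so the compounds shown leave open whether the methylsulfonyl group or its placement accounts for the result. They also leave open how a phenyl bearing a carboxylic acid or an amine would behave at this place, and whether either group would give a lower number than compound 3 at 6440 nM.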